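The compounds below may be only part of what the source reports. "The series", "measured", "known", "first", "only" and "open" are said of these compounds alone.

Three compounds share one core and differ only in the amide-type group. Compound 1 `O=C(CCC(=O)OCCCCCCSc1ccc([N+](=O)[O-])c2nonc12)Nc1ccccc1Cl` gives 2950 nM in an ADME assay on HUVEC cells (Homo sapiens) for cytotoxicity, read by MTT assay, with a stated time of 72 h; a higher number here means a weaker inhibitor, a lower number a stronger inhibitor. Compound 2 `O=C(CCC(=O)OCCCCCCSc1ccc([N+](=O)[O-])c2nonc12)Nc1ccc(Br)cc1` gives 1610 nM in this assay, and compound 3 `Cc1ccc(NC(=O)CCC(=O)OCCCCCCSc2ccc([N+](=O)[O-])c3nonc23)cc1` gives 2340 nM. Compound 2 holds the lowest of the three numbers, but its nearest neighbour compound 3 lies only a 1.5-fold higher number from compound 2 to compound 3 (0.16 log units; within the scatter) away, and the step of a 1.8-fold lower number from compound 1 to compound 2 (0.26 log units; within the scatter) is likewise within the scatter, so the three values cannot be set in order.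

Compound 4 `O=C(CCC(=O)N1CCCCC1)OCCCCCCSc1ccc([N+](=O)[O-])c2nonc12` has not yet been measured in this assay. The change from compound 2 is piperidin-1-yl in place of (4-bromophenyl)amino on a carbonyl carbon. For the measured compounds named here, no measured step touches the amide-type nitrogen in this way; the steps of a 1.8-fold lower number from compound 1 to compound 2 (0.26 log units; within the scatter) and a 1.5-fold higher number from compound 2 to compound 3 (0.16 log units; within the scatter) only exchange one aromatic ring for another or one substituent on an aromatic carbon for another, and both stay within the scatter. On that basis no step beyond the scatter is expected, though the change is larger than any measured one. Compound 4 is therefore estimated at 2200 nM, between 800 nM and 6000 nM, an expected step of a 1.4-fold higher number from compound 2 to compound 4 (0.14 log units; within the scatter).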

Compound 4, half-maximal inhibitory concentration: 1990 nM
Estimate against measurement, compound 4: 1.1-fold (0.04 log units) above, within the range that was stated.
By their numbers in this assay, from the lowest: compounds 2, 4, 3 and 1 (each within the scatter of the next).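

Piperidin-1-yl on this carbonyl carbon exchanges the aromatic ring for a non-aromatic one and removes the amide hydrogen, yet every new step in this assay stays within the scatter (a 1.2-fold higher number from compound 2 to compound 4 (0.09 log units; within the scatter); a 1.2-fold lower number from compound 3 to compound 4 (0.07 log units; within the scatter); a 1.5-fold lower number from compound 1 to compound 4 (0.17 log units; within the scatter)). The earlier compounds shown here only exchanged one substituted phenyl group for another, so they could not show that the number also stays within the scatter when both the aromatic ring and the amide hydrogen are gone. No evidence is available that explains this result.

Because the ring and the amide hydrogen change together here, the compounds shown cannot separate the two, which a (4-bromophenyl)(methyl)amino group could do. They also leave open whether a morpholin-4-yl group, a carboxylic acid or a longer chain at this carbonyl carbon would give a step beyond the scatter.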